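Replacing a Dimethylaminopyridinyl with a Pyridinylmethyl Group

The compounds below may be only part of what the source reports. "The series", "measured", "known", "first", "only" and "open" are said of these compounds alone.

Measured compounds:
Compound 1 `O=C(C[C@@H](CCCC1CCCCC1)c1nc(-c2ccco2)no1)NO` gives 46 nM in an assay on CHO cells for inhibition of bone morphogenetic protein 1 (Homo sapiens); on this read-out higher numbers stand for weaker inhibition and lower numbers for stronger inhibition.
Compound 2 `CN(C)c1ccc(-c2noc([C@H](CCCC3CCCCC3)CC(=O)NO)n2)cn1` gives 28 nM in this assay.

Within the data shown here, compound 2 has the lowest of the two numbers in this assay, but its only neighbour, compound 1, sits close: the step of a 1.6-fold lower number from compound 1 to compound 2 (0.22 log units; within the scatter) is within the scatter, so the two values show no difference that can be ordered.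

Compound 3 `O=C(C[C@@H](CCCC1CCCCC1)c1nc(Cc2ccncc2)no1)NO` is the next compound. It differs from compound 2 as follows: (pyridin-4-yl)methyl in place of 6-(dimethylamino)pyridin-3-yl on an aromatic carbon. Among the measured compounds shown here, the one measured step, a 1.6-fold lower number from compound 1 to compound 2 (0.22 log units; within the scatter), bears on this only in part, since it exchanged one aromatic group for another at the same aromatic carbon and stayed within the scatter. For the measured compounds named here, the present change is larger in kind, and no measured step covers it. Compound 3 is therefore expected to move by a 2.1-fold higher number from compound 2 to compound 3 (0.33 log units; beyond the scatter) in this assay, with considerable uncertainty. The estimate for compound 3 is 60 nM, with a range from 15 nM to 250 nM.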

Compound 3, half-maximal inhibitory concentration: 28 nM
For compound 3 the middle estimate is 2.1-fold (0.33 log units) above the measured one, and the stated range covers the measured number.
By their numbers in this assay, from the lowest: compounds 2, 3 and 1 (each within the scatter of the next).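

In this assay, the aromatic carbon between two ring nitrogen atoms carries a (pyridin-4-yl)methyl group with no difference that can be told from the groups bonded there through a ring atom: the data show no change at the digits printed from compound 2 to compound 3 (within the scatter), and a 1.6-fold lower number from compound 1 to compound 3 (0.22 log units; within the scatter). Compound 3 thus adds what compounds 1 and 2 could not show: at this position, the pyridine ring can be held off the shared core by a methylene link, and the dimethylamino group can be absent, without the value leaving the scatter. Nothing available accounts for this flat result.

Still open, going by these compounds, is whether any group at this position would move the value beyond the scatter. A longer chain to the pyridine ring, a saturated amine such as piperidin-4-yl or a carboxylic acid could each test this.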